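A trifluoro-hydroxy side chain tested for cytotoxicity

The source may report more compounds than this note shows. Statements on the series, on what has been measured and on what is new or still open speak of the compounds shown alone.

Measured compounds:
compound 1, `CS(=O)(=O)c1nn(Cc2nc3cc(Cl)ccc3n2CCCO)c2cnccc12`, a limit of > 100000 nM in an ADME assay on HEp-2 cells (Homo sapiens) for cytotoxicity, with a stated time of 4 days; on this read-out higher numbers stand for lower toxicity in this test and lower numbers for higher toxicity in this test
compound 2, `CC(C)(O)CCCn1c(Cn2nc(S(C)(=O)=O)c3ccncc32)nc2cc(Cl)ccc21`, a limit of > 100000 nM in this assay
compound 3, `COCCOCCn1c(Cn2nc(S(C)(=O)=O)c3ccncc32)nc2cc(Cl)ccc21`, a limit of > 100000 nM in this assay

Compound 3 stands only at a limit in this assay, and the two other values shown are limits as well. The untested compound 4, `CS(=O)(=O)c1nn(Cc2nc3cc(Cl)ccc3n2CCC(O)C(F)(F)F)c2cnccc12`, differs from compound 3 in one place: 2,2,2-trifluoro-1-hydroxyethyl in place of 2-methoxyethoxy on a saturated chain carbon, two bonds along the chain from an aromatic nitrogen. The measured steps on the same side chain bear on this change, but none of them can be read: a step that the two limits leave unreadable from compound 1 to compound 2, a step that the two limits leave unreadable from compound 1 to compound 3 and a step that the two limits leave unreadable from compound 2 to compound 3. Among the measured compounds shown here, the only evidence on them is the limit of > 100000 nM in this assay, at which 3 of the 3 values shown sit. For the measured compounds named here, since every step on this chain ends at the same limit, no step of readable size is expected from compound 3 to compound 4, estimated as a step that the limit leaves unreadable from compound 3 to compound 4. Compound 4 is therefore expected to give about 150000 nM in this assay, estimated between 40000 nM and 500000 nM, most likely again as a limit.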

Compound 4, half-maximal cytotoxic concentration: > 100000 nM
Compound 4: a limit, no number; the forecaster's own chance of this, stated with the estimate: 75%; the middle value does not contradict the limit.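

In this assay compound 4 gives > 100000 nM, which is a limit. Its steps from compound 1, compound 2 and compound 3 therefore cannot be read: the limit of > 100000 nM in this assay, at which 4 of the 4 values shown sit.

The compounds shown leave open whether these side chains differ at all in this assay, as none of the four values is a number.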